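Chloro to Methylamino on the Core of Compound 3

A few compounds are considered here, and "the series" means these few. Any claim that something is new, unique, unknown or untested is made for them only; others in the source may bear on it.

Compound 1, `CC(=O)Nc1nccc(-c2ccncc2)n1`, gives 52%
Compound 2, `CC(C)(C)c1nc(-c2ccccc2)ncc1-c1ccccc1`, gives < 5%
Compound 3, `CC(C)(C)c1ccnc(Cl)n1`, gives < 5%

The three measured compounds were tested in a functional assay on the whole organism for inhibition, with Rattus norvegicus as the target, with stated times of 1 h and 3.5 h, at a dose of 100 mg/kg by the oral route; a higher number here means more inhibition at the dose given (going by the name of the read-out), a lower number less inhibition. Compound 1 gives 52%, the only numerical read-out of the three. For compound 2 the read-out of < 5% is a limit of the assay, not a number. For compound 3 the read-out of < 5% is likewise a limit of the assay, not a number. Thus compound 3 stands at the floor of this assay, and (the limit of < 5% in this assay, at which 2 of the 3 values shown sit).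

Compound 4, `CNc1nccc(C(C)(C)C)n1`, has not yet been measured. It differs from compound 3 in one place: methylamino in place of chloro on an aromatic carbon. Among the compounds with values here, no measured pair shares this change, so the size of the step is open. Compound 3 sits at a limit, so any move for compound 4 can only be upward or none beyond the scatter. The step of a number at least 5 percentage points higher from compound 3 to compound 4 (that floor lies within the scatter) is expected to be small, likely within the scatter. Compound 4 is estimated at 10%, with a range from 0% to 30%, and a real chance that the assay again reports only a limit.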

Compound 4, a percentage reported as inhibition, in the whole organism at one dose (the size of the read-out at that dose, not a potency): 34%
Estimate against measurement, compound 4: 24 percentage points below; measured number above the stated range.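

In this assay, methylamino in place of chloro, on an aromatic carbon between two ring nitrogen atoms, gives a number at least 29 percentage points higher from compound 3 to compound 4 (beyond the scatter). This is the first step among these compounds that changes only one place, and it shows that this position answers to the exchange, with the group of 4 heavy atoms left as it stands. Compound 3 gives < 5%, which is a limit and not a number, so the step has a lower bound and no fixed size: the limit of < 5% in this assay, at which 2 of the 4 values shown sit.

How a plain amine, a methoxy group or a longer chain on the nitrogen would read at this position stays open, so the compounds shown cannot separate the part played by the nitrogen from that of its methyl. Going by these compounds, whether the same exchange would carry over to another core also remains unknown.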